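A few compounds are considered here, and "the series" means these few. Any claim that something is new, unique, unknown or untested is made for them only; others in the source may bear on it.

Three compounds share one core and differ only in the group on the carbonyl carbon. Compound 1 `O=C(O)C1CCC2(CC1)OOC1(CCCCC1)OO2` carries a hydroxy there, and in a functional assay on HeLa cells (Homo sapiens) for cytotoxicity (on this read-out lower numbers stand for stronger inhibition and higher numbers for weaker inhibition), compound 1 gives 120000 nM. Compound 2 `NC(=O)C1CCC2(CC1)OOC1(CCCCC1)OO2` has amino in place of hydroxy on the carbonyl carbon; in this assay compound 2 gives 115000 nM. Compound 3 `CCCNC(=O)C1CCC2(CC1)OOC1(CCCCC1)OO2` has propylamino in place of hydroxy on the carbonyl carbon; in this assay compound 3 gives 117000 nM. Compound 3 therefore stands alongside the other two: the steps of a 1.0-fold lower number from compound 1 to compound 3 (0.01 log units; within the scatter) and a 1.0-fold higher number from compound 2 to compound 3 (0.01 log units; within the scatter) both lie within the scatter, as does a 1.0-fold lower number from compound 1 to compound 2 (0.02 log units; within the scatter).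

Compound 4 `CN(C)CCNC(=O)C1CCC2(CC1)OOC1(CCCCC1)OO2` is reached from compound 3 by a change on a saturated chain carbon, two bonds along the chain from an amide-type nitrogen: dimethylamino in place of methyl on a saturated chain carbon, two bonds along the chain from an amide-type nitrogen. The step that bears most on this chain is a 1.0-fold higher number from compound 2 to compound 3 (0.01 log units; within the scatter), where the whole propyl entered without any move beyond the scatter, and the swaps on the carbonyl carbon were equally flat. Nothing here suggests the number will shift, so the step from compound 3 to compound 4 in this assay is expected to be no change at the digits printed from compound 3 to compound 4 (within the scatter), within the scatter. Compound 4 is estimated at 117000 nM, with a range from 58000 nM to 235000 nM.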

Compound 4, half-maximal inhibitory concentration: 135000 nM
Estimate against measurement, compound 4: 1.2-fold (0.06 log units) below; measured number inside the range.
By their numbers in this assay, from the lowest: compounds 2, 3, 1 and 4 (each within the scatter of the next).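

In this assay, dimethylamino in place of methyl on a saturated chain carbon, two bonds along the chain from an amide-type nitrogen, gives a 1.2-fold higher number from compound 3 to compound 4 (0.06 log units; within the scatter), so this position accepts a group with a nitrogen and a hydrogen-bond acceptor without a move beyond the scatter. The wider comparisons agree, with 2-(dimethylamino)ethyl in place of hydrogen on the amide-type nitrogen giving a 1.2-fold higher number from compound 2 to compound 4 (0.07 log units; within the scatter) and (2-(dimethylamino)ethyl)amino in place of hydroxy on the carbonyl carbon giving a 1.1-fold higher number from compound 1 to compound 4 (0.05 log units; within the scatter), so the flat picture seen with propyl also holds for a chain carrying an amine. No measurement shown offers an explanation for this flatness.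

From the compounds shown here alone, whether a carboxylic acid or a morpholine in place of the dimethylamino, or a longer chain, would move the number beyond the scatter remains open. The compounds shown also leave open whether any change to the shared core would do so.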